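Sulfonamide benzoic acids: aryl to styryl exchange

A few compounds are considered here, and "the series" means these few. Any claim that something is new, unique, unknown or untested is made for them only; others in the source may bear on it.

Working notes on two measured compounds and one awaiting measurement. Compound 1 `CCCCCCCCS(=O)(=O)Nc1cc(-c2ccccc2F)ccc1C(=O)O` and compound 2 `CCCCCCCCS(=O)(=O)Nc1ccc(-c2ccc(CCCC)cc2)cc1C(=O)O` carry the same shared core and differ in the group attached to it. In an assay on mitochondria (strain BALB/c) for inhibition of glycerol-3-phosphate acyltransferase 1, mitochondrial (Mus musculus), read by scintillation counting, with a stated time of 10 min (on this read-out higher numbers stand for weaker inhibition and lower numbers for stronger inhibition), compound 1 gives 47200 nM, while compound 2 gives 9000 nM. Compound 2 thus holds the lower of the two numbers, and since its gap to compound 1 lies beyond the scatter, compound 2 is the stronger inhibitor of the pair. For the measured compounds named here, no two measured compounds differ in a single place, so no isolated step has been quantified.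

Compound 3 `CCCCCCCCS(=O)(=O)Nc1ccc(/C=C/c2ccc(OC)cc2)cc1C(=O)O` is next. Compared with compound 2 the change is: 2-(4-methoxyphenyl)ethenyl in place of 4-butylphenyl on an aromatic carbon. The entering group keeps one six-membered aromatic ring of carbon only and adds one double bond outside aromatic rings and one hydrogen-bond acceptor.

Going by the values given here, with no comparable step among the measured compounds, the expectation for compound 3 in this assay is a modest shift in either direction or none beyond the scatter. The expected step is a 1.1-fold lower number from compound 2 to compound 3 (0.05 log units; within the scatter). Compound 3 is estimated at 8000 nM, with a range of 2500 nM to 25000 nM.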

Compound 3, half-maximal inhibitory concentration: 37100 nM
For compound 3 the middle estimate is 4.6-fold (0.67 log units) below the measured one; the measured number lies above the stated range.
By their numbers in this assay, from the lowest: compound 2; then compounds 3 and 1 (each within the scatter of the next).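

For the compounds shown here, this is the first single-place step that can be read: in this assay, 2-(4-methoxyphenyl)ethenyl in place of 4-butylphenyl brings a 4.1-fold higher number from compound 2 to compound 3 (0.62 log units; beyond the scatter) on this aromatic carbon, meta to a carboxy group. Both groups have the same heavy-atom count and each carries one six-membered aromatic ring of carbon only, so these shared counts alone do not preserve the number of compound 2 at this position. No measurement on hand bears on what lies behind the step.

The entering group differs from the leaving one in two ways at once, the ethenyl link and the methoxy group in place of the butyl chain, and the compounds shown do not separate these two changes. Open questions are where 4-methoxyphenyl or 2-(4-butylphenyl)ethenyl at this position would fall relative to compound 2 and compound 3, and whether an amine or a carboxylic acid on the terminal aromatic ring in place of methoxy would move the number in either direction.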